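This account rests on a few compounds, and the source may have more. Where it says the series, first, only, none or still open, it means among the compounds named here.

In a functional assay on DU-145 cells (Homo sapiens) for inhibition, read by MTT assay, with a stated time of 24 h (a higher number here means a weaker inhibitor, a lower number a stronger inhibitor), three compounds have been measured:

Compound 1, `CCOC(=O)C1=Cc2ccccc2OC1(OCc1cn(CC(=O)Nc2ccccc2Br)nn1)C(F)(F)F`: > 150000 nM, a limit of the assay.
Compound 2, `CCOC(=O)C1=Cc2ccccc2OC1(OCc1cc(-c2ccc(Br)cc2)no1)C(F)(F)F`: 71700 nM.
Compound 3, `O=C(O)C1=Cc2ccccc2OC1(OCc1cc(-c2ccc(F)cc2F)no1)C(F)(F)F`: > 150000 nM, a limit of the assay.

Among the measured compounds shown here, compound 2 stands as the only compound with a numerical value in this assay; the other two results sit at the limit of > 150000 nM in this assay, at which 2 of the 3 values shown sit, so no measured step separates one full value from another. Compound 4, `CCOC(=O)C1=Cc2ccccc2OC1(OCc1cc(-c2ccc(F)cc2)no1)C(F)(F)F`, differs from compound 2 in one place: fluoro in place of bromo on an aromatic carbon. For the measured compounds named here, no pair among the measured compounds shows the effect of this change, so its size cannot be read from the data. The expectation for the step in this assay from compound 2 to compound 4 is therefore a small one, at most a modest loss of inhibition that may not exceed the scatter, and the step from compound 2 to compound 4 is estimated as a 1.4-fold higher number from compound 2 to compound 4 (0.14 log units; within the scatter). For compound 4 the expected half-maximal inhibitory concentration in this assay is 100000 nM, with a range from 40000 nM to 150000 nM.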

Compound 4, half-maximal inhibitory concentration: 53500 nM
Compound 4: the middle estimate sits 1.9-fold (0.27 log units) above what was measured; measured number inside the range.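

In this assay, among the compounds shown here, fluoro in place of bromo on an aromatic carbon, para to a large group, gives the first step here that can be read between two full values: a 1.3-fold lower number from compound 2 to compound 4 (0.13 log units; within the scatter). At this position, therefore, the data do not tell bromo and fluoro apart, and this exchange alone does not separate the two compounds. No other step can be read, as the remaining results are limits and not numbers: the limit of > 150000 nM in this assay, at which 2 of the 4 values shown sit.

The compounds shown leave open whether an amine or a methoxy group in this place, or plain hydrogen, would move the number beyond the scatter. Also open, going by these compounds, is whether the same exchange would read alike on a core carrying a carboxylic acid in place of the ethyl ester.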